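Working notes: 3-cyanophenyl in place of 3,4-dimethylphenyl

The source may hold more compounds than are shown below. What is called first, only, known or untested is meant among the compounds shown, and "the series" means these compounds.

- Compound 1 `COc1cc(-c2ccnc3cc(-c4c[nH]c5ccccc45)nn23)cc(OC)c1OC`: 195 nM
- Compound 2 `COc1cc(-c2ccnc3cc(-c4ccc(C)c(C)c4)nn23)cc(OC)c1OC`: 241 nM

In a functional assay on HeLa cells (Homo sapiens) for inhibition, read by CCK-8 assay, with a stated time of 48 h (on this read-out higher numbers stand for weaker inhibition and lower numbers for stronger inhibition), compound 2 gives 241 nM and compound 1 gives 195 nM, two values within the scatter of each other. With only these two numbers, compound 2 cannot be placed apart from compound 1.

The next compound to be read is compound 3 `COc1cc(-c2ccnc3cc(-c4cccc(C#N)c4)nn23)cc(OC)c1OC`, which carries 3-cyanophenyl in place of 3,4-dimethylphenyl on an aromatic carbon. The shared core is unchanged.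

Among the measured compounds shown here, one measured step bears on this change: a 1.2-fold higher number from compound 1 to compound 2 (0.09 log units; within the scatter). It exchanges the group on the same aromatic carbon, and it stays within the scatter. For the measured compounds named here, no measured compound carries a nitrile, so that single step is weak evidence and the range is kept wide.

In this assay no step beyond the scatter is expected, and no direction is favoured with confidence. The estimated step is a 1.2-fold higher number from compound 2 to compound 3 (0.07 log units; within the scatter). For compound 3 the expected value is 280 nM, with an estimated range of 110 nM to 750 nM.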

Compound 3, half-maximal inhibitory concentration: > 10000 nM
Compound 3 was reported as a limit; the forecaster's own chance of this, stated with the estimate: 2%; middle value at least 35-fold (1.55 log units) from the limit.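

In this assay compound 3 stands only as a limit, > 10000 nM, and not as a number: the limit of > 10000 nM in this assay, at which 1 of the 3 values shown sits.

Even read as limits, the new steps show that this aromatic carbon of the five-membered ring does not accept every aryl group: 3-cyanophenyl in place of 3,4-dimethylphenyl gives an at least 41-fold higher number from compound 2 to compound 3 (1.61 log units; beyond the scatter), and 3-cyanophenyl in place of 1H-indol-3-yl gives an at least 51-fold higher number from compound 1 to compound 3 (1.70 log units; beyond the scatter). Among the compounds shown here, the earlier pair gave no sign of this, since the only step then available was a 1.2-fold higher number from compound 1 to compound 2 (0.09 log units; within the scatter). The leaving and entering groups in the first of these changes have the same count of heavy atoms and the same kind of ring, so that count does not separate them, and the nitrile with its hydrogen-bond acceptor is what is new.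

The compounds shown cannot tell whether the loss follows the nitrile itself or the absence of the two methyl groups, and a methoxy group or an amine on the same phenyl ring would bear on that question. On these data alone, how far compound 3 lies beyond its limit also stays open.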